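Swapping the Ring Substituent on a Piperazine Dithiocarbamate

The source may report more compounds than this note shows. Statements on the series, on what has been measured and on what is new or still open speak of the compounds shown alone.

Compound 1 `Nc1nc(N)c2cc(CSC(=S)N3CCN(C4CCCCC4)CC3)ccc2n1`: 8400 nM
Compound 2 `Cc1ccccc1N1CCN(C(=S)SCc2ccc3nc(N)nc(N)c3c2)CC1`: 11800 nM
Compound 3 `CC(=O)c1ccc(N2CCN(C(=S)SCc3ccc4nc(N)nc(N)c4c3)CC2)cc1`: 8260 nM

These three compounds share one core and differ only in the group on an amine nitrogen in a ring. In a functional assay on HCT-116 cells (Homo sapiens) for antiproliferative activity, read by MTT assay, with a stated time of 72 h (a higher number here means a weaker inhibitor, a lower number a stronger inhibitor), compound 2 gives 11800 nM. The step of a 1.4-fold higher number from compound 1 to compound 2 (0.15 log units; within the scatter) and the step of a 1.4-fold lower number from compound 2 to compound 3 (0.15 log units; within the scatter) both fall within the scatter, as does a 1.0-fold lower number from compound 1 to compound 3 (0.01 log units; within the scatter), so the three numbers cannot be told apart. Compound 4 `Nc1nc(N)c2cc(CSC(=S)N3CCN(c4ncccn4)CC3)ccc2n1` is not yet measured; its change from compound 2 is pyrimidin-2-yl in place of 2-methylphenyl on an amine nitrogen in a ring. Because a 1.4-fold higher number from compound 1 to compound 2 (0.15 log units; within the scatter) and a 1.4-fold lower number from compound 2 to compound 3 (0.15 log units; within the scatter) show nothing beyond the scatter for changes at this same place, no step beyond the scatter is expected in this assay here either. Compound 4 is therefore expected to give about 9500 nM, with a range from 4000 nM to 22000 nM, meaning a 1.2-fold lower number from compound 2 to compound 4 (0.09 log units; within the scatter).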

Compound 4, half-maximal inhibitory concentration: 5840 nM
Compound 4: middle estimate off by 1.6-fold (0.21 log units), on the high side; measured number inside the range.
By their numbers in this assay, from the lowest: compounds 4, 3, 1 and 2 (each within the scatter of the next, the first and the last beyond it).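

In this assay, this position gives its first step beyond the scatter: pyrimidin-2-yl in place of 2-methylphenyl brings a 2.0-fold lower number from compound 2 to compound 4 (0.31 log units; beyond the scatter) and shows that the group on this amine nitrogen can shift the number modestly. The same group gives only a 1.4-fold lower number from compound 3 to compound 4 (0.15 log units; within the scatter) against 4-acetylphenyl and a 1.4-fold lower number from compound 1 to compound 4 (0.16 log units; within the scatter) against cyclohexyl, so compound 4 separates from compound 2 alone. Nothing measured here explains this step. The compounds shown leave open what an unsubstituted phenyl or a pyridin-2-yl group would give on this nitrogen, and whether the ring nitrogens of pyrimidin-2-yl matter for the step.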